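Swapping the aryl sulfone for a fused bicyclic group

This account rests on a few compounds, and the source may have more. Where it says the series, first, only, none or still open, it means among the compounds named here.

Measured so far:
- compound 1, `CN1CCC(n2cc(S(=O)(=O)c3ccccc3)c3cccnc32)C1`: 2040 nM
- compound 2, `O=S(=O)(c1ccccc1)c1cn(C2CCCNC2)c2ncccc12`: 47 nM

Both compounds were tested in a functional assay on HeLa cells for agonist activity at 5-hydroxytryptamine receptor 6 (Homo sapiens), read by cAMP accumulation and immunoassay; on this read-out lower numbers stand for an effect already at smaller amounts and higher numbers for an effect only at larger amounts of compound. Compound 2 has the lowest number of the two, and its nearest neighbour, compound 1, is separated from it by a 43-fold lower number from compound 1 to compound 2 (1.64 log units; beyond the scatter), a change that lies in the ring attached to the aromatic nitrogen.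

Compound 3, `O=S(=O)(C1=C(Cl)NC2SC=CN12)c1cn(C2CCCNC2)c2ncccc12`, is built on compound 2 by a change in a different part of the molecule: a group of 9 heavy atoms (5 carbon, 2 nitrogen, 1 sulfur, 1 chlorine; 2 five-membered non-aromatic rings with 2 hetero atoms each) in place of a group of 6 heavy atoms (6 carbon; one six-membered aromatic ring of carbon only), on a sulfonyl sulfur. Within the data shown here, the only step measured so far, from compound 1 to compound 2, concerns the saturated amine ring and not the group on the sulfonyl sulfur, so it gives no direct guidance for this change. Among the measured compounds shown here, with no measured precedent for altering that group, the expectation rests on the size of the change alone: a larger, more polar bicyclic group enters where a plain phenyl stood. Compound 3 is therefore expected to show a moderately higher number, a step of a 3.2-fold higher number from compound 2 to compound 3 (0.50 log units; beyond the scatter), with the estimate for compound 3 being 150 nM, in the range 30 nM to 1000 nM.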

Compound 3, half-maximal effective concentration: 66 nM
Estimate against measurement, compound 3: 2.3-fold (0.36 log units) above, within the range that was stated.
By their numbers in this assay, from the lowest: compounds 2 and 3 (each within the scatter of the next); then compound 1.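

In this assay, the group on the sulfonyl sulfur changes from phenyl to a group of 9 heavy atoms with 2 five-membered non-aromatic rings, and the outcome is a 1.4-fold higher number from compound 2 to compound 3 (0.15 log units; within the scatter), so compound 2 and compound 3 cannot be told apart on this read-out. Among these compounds, the earlier step changed only the ring on the aromatic nitrogen, so this pair gives the first reading at the sulfonyl sulfur: here, a group that brings in nitrogen, sulfur, chlorine and a hydrogen-bond donor, and has no aromatic ring of carbon, replaces phenyl without a shift beyond the scatter. No measurement is available to explain why the two numbers stay so close.

The compounds shown leave open whether a much smaller group on the sulfonyl sulfur, such as methyl, or a phenyl ring carrying an amine would also keep the number in this range. They also leave open whether the chlorine in the entering group matters, which the same group with hydrogen in its place could show.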